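The source may report more compounds than this note shows. Statements on the series, on what has been measured and on what is new or still open speak of the compounds shown alone.

In a functional assay on the whole organism (strain Hartley) for inhibition, with Cavia porcellus as the target, with stated times of 15 min and 2 min (a higher number here means that more compound is needed for the effect, a lower number that less compound is needed), compound 2 (`CCCCC1([C@@H](O)/C=C/C2CCC(=O)[C@@H]2CCCCSCC(=O)OCC)CCC1`) gives > 0.672 mg/kg as a limit of the assay and not a number. Compound 1 (`CCCCC1([C@@H](O)/C=C/C2CCC(=O)[C@@H]2CCCCCCC(=O)O)CCC1`) gives 0.0139 mg/kg as a measured value. Compound 3 (`CCCCC1([C@@H](O)/C=C/C2CCC(=O)[C@@H]2CCCCSCC(=O)O)CCC1`) differs from compound 2 by hydrogen in place of ethyl on an oxygen next to a carbonyl group and so carries carboxy in place of ethoxycarbonyl, as compound 1 does. Among the compounds with values here, the one measured step that bears on this, an at least 48-fold higher number from compound 1 to compound 2 (1.68 log units; beyond the scatter), is large, but it also includes the sulfanyl change in the chain, so only part of it should return. The expected move in this assay is towards a lower number, as an at least 5.6-fold lower number from compound 2 to compound 3 (0.74 log units; beyond the scatter) in estimate. For compound 3 the expected value is 0.12 mg/kg with an estimated range from 0.02 mg/kg to 0.7 mg/kg at most.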

Compound 3, dose for half-maximal effect: 0.606 mg/kg
The estimate for compound 3 lay 5.1-fold (0.70 log units) below the measured number; low and high end bracket the measured number.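

In this assay hydrogen in place of ethyl on an oxygen next to a carbonyl group gives an at least 1.1-fold lower number from compound 2 to compound 3 (0.04 log units; that floor lies within the scatter) and so shows no gain beyond the scatter. Carboxy alone does not restore the activity of compound 1, as the sulfur-containing chain still costs a 44-fold higher number from compound 1 to compound 3 (1.64 log units; beyond the scatter) in this comparison. The true size of the ester step stays unresolved, because compound 2 is reported only as a limit: the limit of > 0.672 mg/kg in this assay, at which 1 of the 3 values shown sits.

Still open, from the compounds shown here alone, is whether an ether oxygen in place of the sulfanyl sulfur would keep the number near that of compound 1. Also open, going by these compounds, is how an amide in place of the carboxy would read.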